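The source may report more compounds than this note shows. Statements on the series, on what has been measured and on what is new or still open speak of the compounds shown alone.

Compound 1, `Cc1c(Cc2ccccc2)c(=O)oc2cc(OCC(O)CNc3ccc(Br)cc3)ccc12`, gives a limit rather than a number in an ADME assay on A549 cells (Homo sapiens) for cytotoxicity, read by CellTiter-Glo; on this read-out lower numbers stand for higher toxicity in this test and higher numbers for lower toxicity in this test: > 100000 nM. Compound 2, `Cc1c(Cc2ccc(Cl)cc2)c(=O)oc2cc(OCC(O)CN3CCC(C(N)=O)CC3)ccc12`, gives 40000 nM in this assay.

Among the two values shown, compound 2 thus stands on the only number; the other value is a limit, as the limit of > 100000 nM in this assay, at which 1 of the 2 values shown sits, records. No step between measured compounds that differ in one place is available, so the two values can only be set side by side, and no cause for their difference is given.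

Compound 3, `Cc1c(Cc2cccc3ccccc23)c(=O)oc2cc(OCC(O)CN3CCC(C(N)=O)CC3)ccc12`, has not yet been measured in this assay. It differs from compound 2 in one place: naphthalen-1-yl in place of 4-chlorophenyl on a saturated chain carbon bound to an aromatic carbon.

Among the measured compounds shown here, with no measured step to lean on, the expectation for compound 3 rests on the value of compound 2 alone. Compound 3 is expected to give about 25000 nM in this assay, within a range from 8000 nM to 100000 nM. The estimated step of a 1.6-fold lower number from compound 2 to compound 3 (0.20 log units; within the scatter) is expected to be small, toward lower numbers, and not clearly beyond the usual scatter of repeated measurements.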

Compound 3, half-maximal cytotoxic concentration: 42400 nM
The estimate for compound 3 lay 1.7-fold (0.23 log units) below the measured number; measured number inside the range.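

In this assay, among the compounds shown here, putting naphthalen-1-yl in place of 4-chlorophenyl on a saturated chain carbon bound to an aromatic carbon gives a 1.1-fold higher number from compound 2 to compound 3 (0.03 log units; within the scatter), which is the first reading of a change at this position alone. The exchange swaps one six-membered aromatic ring bearing chlorine for two aromatic rings of carbon only, and the read-out stays within the usual scatter, so at this position the larger group and the loss of chlorine together leave no visible mark on this test. Nothing shown gives a cause for this outcome.

The pair changes the number of rings and removes the chlorine at once, so it cannot tell whether each change alone would also leave the read-out where it is, or whether the two happen to offset each other. It also leaves open whether a group of another kind at this position, such as a pyridin-3-yl ring, a carboxylic acid or a longer chain, would stay within the scatter of these two compounds.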